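A few compounds are considered here, and "the series" means these few. Any claim that something is new, unique, unknown or untested is made for them only; others in the source may bear on it.

Measured so far:
compound 1, `CCCCOCCCCCCCCCc1cc2cn([C@H]3C[C@H](O)[C@@H](CO)O3)c(=O)nc2o1`: 20000 nM
compound 2, `CCCCCOCCCCCCCCCc1cc2cn([C@H]3C[C@H](O)[C@@H](CO)O3)c(=O)nc2o1`: 10000 nM

In a functional assay on HEL cells (Homo sapiens) for cytotoxicity (on this read-out higher numbers stand for lower toxicity in this test and lower numbers for higher toxicity in this test), compound 1 gives 20000 nM and compound 2 gives 10000 nM. Within the data shown here, compound 2 carries the smaller of the two numbers, yet the only measured step, a 2.0-fold lower number from compound 1 to compound 2 (0.30 log units; within the scatter), lies within the scatter, so the two compounds cannot be told apart on this read-out. Compound 3, `CC(C)CCOCCCCCCCCCc1cc2cn([C@H]3C[C@H](O)[C@@H](CO)O3)c(=O)nc2o1`, has the same atoms as compound 2 joined differently: isopropyl in place of propyl on a saturated chain carbon, two bonds along the chain from an oxygen on a saturated carbon. Among the measured compounds shown here, the one measured step bears on this change only loosely, since it added a carbon to the chain rather than rearranging it, and it stayed within the scatter. On that basis no step beyond the scatter is expected in this assay, and the step from compound 2 to compound 3 is estimated as no change at the digits printed from compound 2 to compound 3 (within the scatter). Compound 3 is therefore expected to give 10000 nM, in a range from 5000 nM to 40000 nM.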

Compound 3, minimum cytotoxic concentration: 10000 nM
Compound 3: middle estimate and measured number agree at the digits printed, and the stated range covers the measured number.
By their numbers in this assay, from the lowest: compounds 2, 3 and 1 (each within the scatter of the next).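

In this assay, isopropyl in place of propyl, two bonds along the chain from an oxygen on a saturated carbon, shows no change at the digits printed from compound 2 to compound 3 (within the scatter). Among these compounds, the earlier step only added a carbon, so this is the first sign that joining the same atoms differently at this place also leaves the number within the scatter. The other new step, a 2.0-fold lower number from compound 1 to compound 3 (0.30 log units; within the scatter), is also within the scatter, so the three compounds cannot be told apart on this read-out, and no measurement at hand bears on why this is so.

On these data alone, whether a larger branched group such as tert-butyl, or a ring such as cyclopentyl, would give a step beyond the scatter at this place remains open. So does the effect of an amine or a carboxylic acid there, or of a much longer chain.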